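Estimating a Phenyl Swap on a Carbonyl Carbon

This account rests on a few compounds, and the source may have more. Where it says the series, first, only, none or still open, it means among the compounds named here.

- compound 1 `CC(=O)O[C@H]1CC[C@]2(C)[C@H](CC[C@@](C)(O)[C@H]2CC[C@@H]2C(C)=CC[C@@H]3C(C)=CC[C@@H]3C2(C)C)OC1(C)C`: 39200 nM
- compound 2 `CC1=CC[C@H]2[C@@H]1CC=C(C)[C@@H](CC[C@H]1[C@]3(C)CC[C@H](OC(=O)CCC(=O)O)C(C)(C)O[C@H]3CC[C@@]1(C)O)C2(C)C`: 29600 nM

Both numbers come from a functional assay on MDA-MB-231 cells (Homo sapiens) for antiproliferative activity, read by MTT assay, with a stated time of 72 h; on this read-out higher numbers stand for weaker inhibition and lower numbers for stronger inhibition. Only these two compounds have been measured so far. Compound 2, at 29600 nM, lies within the scatter of compound 1, at 39200 nM, so neither can be called the stronger.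

The next compound is compound 3 `CC1=CC[C@H]2[C@@H]1CC=C(C)[C@@H](CC[C@H]1[C@]3(C)CC[C@H](OC(=O)c4ccccc4)C(C)(C)O[C@H]3CC[C@@]1(C)O)C2(C)C`, which keeps the shared core of compound 2. The structural change is phenyl in place of 2-carboxyethyl on a carbonyl carbon.

Among the compounds with values here, one measured step bears on this, a 1.3-fold lower number from compound 1 to compound 2 (0.12 log units; within the scatter). It altered the same part of the molecule and stayed within the scatter. That is thin evidence, and neither measured compound carries a phenyl, so the direction of any shift cannot be read from the data. In this assay, no clear change is therefore expected, and the estimated step is a 1.2-fold lower number from compound 2 to compound 3 (0.07 log units; within the scatter). The range is kept wide to allow for the new ring. For compound 3 the estimated value is 25000 nM, with an expected range from 10000 nM to 60000 nM.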

Compound 3, half-maximal inhibitory concentration: 18400 nM
Estimate against measurement, compound 3: 1.4-fold (0.13 log units) above; the range from low to high includes it.
By their numbers in this assay, from the lowest: compounds 3, 2 and 1 (each within the scatter of the next, the first and the last beyond it).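

In this assay, a six-membered aromatic ring can sit on this carbonyl carbon with no loss of inhibition: replacing 2-carboxyethyl with phenyl gives a 1.6-fold lower number from compound 2 to compound 3 (0.21 log units; within the scatter), so compound 2 and compound 3 cannot be told apart. Compared with the smallest group shown, the picture differs slightly, as phenyl in place of methyl gives a 2.1-fold lower number from compound 1 to compound 3 (0.33 log units; beyond the scatter), the only step so far that clears the scatter, and a modest one, showing that the group on this carbonyl carbon can shift the read-out towards stronger inhibition. Nothing available here explains this step.

The compounds shown leave open whether the aromatic ring itself counts, or whether a saturated cyclohexyl ring or a benzyl group on the same carbonyl carbon would read the same. Also open, from the compounds shown here alone, is how an amine at the end of a chain would read, and whether a fluorine or methoxy group on the phenyl ring would carry the number beyond the scatter of compound 2.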